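The source may hold more compounds than are shown below. What is called first, only, known or untested is meant among the compounds shown, and "the series" means these compounds.

Compound 1 `Cc1cc(C)c2sc(NC(=O)c3ccc(C(F)(F)F)cc3)nc2c1` is the starting point of this step. In a functional assay on MDA-MB-231 cells (Homo sapiens) for antiproliferative activity, read by sulforhodamine B assay (on this read-out lower numbers stand for stronger inhibition of growth and higher numbers for weaker inhibition of growth), compound 1 gives 0.45 ug/mL, the lowest of the two numbers reported here. Compound 3 `O=C(Nc1nc2ccc([N+](=O)[O-])cc2s1)c1ccc(C(F)(F)F)cc1` gives 1.89 ug/mL in this assay, a higher number than compound 1 by a margin beyond the usual scatter of the measurement. Compound 2 `COc1ccccc1NC(=O)Nc1nc2ccc(F)cc2s1` gives only a limit of the assay, > 10 ug/mL, and no number; the same limit appears as the limit of > 10 ug/mL in this assay, at which 1 of the 3 values shown sits. Compound 4 `Cc1cc(C)c2sc(NC(=O)c3ccc([N+](=O)[O-])cc3)nc2c1` has not yet been measured. It differs from compound 1 in one place: nitro in place of trifluoromethyl on an aromatic carbon. Among the compounds with values here, no pair of measured compounds shows this same change, so its effect cannot be read off any step already taken. The expectation is therefore cautious: the step of a 1.6-fold higher number from compound 1 to compound 4 (0.19 log units; within the scatter) is expected to stay within or only just beyond the scatter, with the number drifting slightly upward. Compound 4 is estimated to give about 0.7 ug/mL in this assay, with a likely range from 0.25 ug/mL to 2.5 ug/mL.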

Compound 4, concentration for 50% growth inhibition: 0.29 ug/mL
Estimate against measurement, compound 4: 2.4-fold (0.38 log units) above, and the stated range covers the measured number.
By their numbers in this assay, from the lowest: compounds 4 and 1 (each within the scatter of the next); then compound 3. At a limit, above all of these: compound 2.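

In this assay, the core of compound 1 now has its first measured change in a single place: nitro in place of trifluoromethyl on the aromatic carbon gives a 1.6-fold lower number from compound 1 to compound 4 (0.19 log units; within the scatter). On this core and at this carbon, the two groups therefore cannot be told apart: the swap removes fluorine and adds hydrogen-bond acceptors, yet the two numbers stay within the scatter of each other. No measurement shown here bears on why this is so.

On these data alone, whether an amine or a carboxylic acid on this same carbon would keep the number in this range remains open. It is also open whether nitro and trifluoromethyl would match in the same way on a different core, since the compounds shown offer only this one pair.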